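The compounds below may be only part of what the source reports. "The series", "measured", "known", "first", "only" and "open" are said of these compounds alone.

Measured so far in an ADME assay on microsomes from liver (Rattus norvegicus) for metabolic stability; on this read-out lower numbers stand for a shorter-lived compound and higher numbers for a longer-lived compound:
Compound 1 `CC(C)C(Nc1nccs1)c1ccc(-c2ccc3cccc(F)c3c2)[nH]c1=O` gives 0.07 h.
Compound 2 `CCn1ncc2c(F)cc(-c3ccc(C(CC)(CC)c4ncn(C)n4)c(=O)[nH]3)cc21` reaches only a limit of the assay, > 3 h.
Compound 3 `CCn1ncc2c(F)cc(-c3ccc(C(CC)(CC)c4nnc[nH]4)c(=O)[nH]3)cc21` likewise reaches only a limit of the assay, > 3 h.

Compound 1 is the only one of the three with an actual number, and so it is the sole fixed point among the values shown. The other two values sit at the limit of > 3 h in this assay, at which 2 of the 3 values shown sit.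

Compound 4 `Cc1nc(C(c2ccc(-c3ccc4cccc(F)c4c3)[nH]c2=O)C(C)C)[nH]c1C` has not yet been measured. It differs from compound 1 in one place: 4,5-dimethyl-1H-imidazol-2-yl in place of (1,3-thiazol-2-yl)amino on a saturated chain carbon bound to an aromatic carbon and a saturated chain carbon. Going by the values given here, the only step recorded between measured compounds, a step that the two limits leave unreadable from compound 2 to compound 3, concerns a 4H-1,2,4-triazol-3-yl in place of a 1-methyl-1H-1,2,4-triazol-3-yl, a different change from the one leading to compound 4, and both of its ends are limits, so its size cannot be read. Among the compounds with values here, no measured step therefore speaks directly to the change from compound 1 to compound 4, and the expectation rests on compound 1 alone. The estimate for compound 4 in this assay is 0.15 h, between 0.04 h and 0.6 h. This means a step of a 2.1-fold higher number from compound 1 to compound 4 (0.33 log units; beyond the scatter) is expected, which stays within the usual scatter, so compound 4 is expected to remain short-lived like compound 1.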

Compound 4, half-life: 0.0733 h
Compound 4: middle estimate off by 2.0-fold (0.31 log units), on the high side; low and high end bracket the measured number.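

In this assay, putting 4,5-dimethyl-1H-imidazol-2-yl in place of (1,3-thiazol-2-yl)amino gives a 1.0-fold higher number from compound 1 to compound 4 (0.02 log units; within the scatter), so at this place, on a saturated chain carbon bound to an aromatic carbon and a saturated chain carbon, the swap leaves the read-out where it was. Going by these compounds alone, this is the first step in the set that can be read, as the only earlier step between measured compounds has a limit at both ends and cannot be read. Nothing shown accounts for why a group without sulfur and with a different count of hydrogen-bond acceptors leaves the half-life unchanged.

As far as these compounds go, whether a carboxylic acid or a simple amine at this place would give a read-out different from those of compound 1 and compound 4 stays open. Also open, from the compounds shown here alone, is which part of the structure separates compound 1 from compound 2 and compound 3, as these differ from compound 1 in more than one place and cannot be compared with it directly.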